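The compounds below may be only part of what the source reports. "The series", "measured", "known", "first", "only" and "open" are said of these compounds alone.

Measured compounds:
compound 1, `Cc1nsc2c1nc(SCc1ccccc1)n2[C@H]1C[C@H](O)[C@@H](CO)O1`: > 100000 nM
compound 2, `OC[C@H]1O[C@@H](n2c(SCc3ccccc3)nc3cnsc32)C[C@@H]1O`: > 100000 nM
compound 3, `CSc1nc2snc(C)c2n1[C@H]1C[C@H](O)[C@@H](CO)O1`: 30000 nM

All three were tested in a functional assay on KB cells (Homo sapiens) for antiproliferative activity; a lower number here means a stronger inhibitor, a higher number a weaker inhibitor. For compound 1 the value > 100000 nM is a limit of the assay, not a number. For compound 2 the value > 100000 nM is likewise a limit. The change from compound 1 to compound 2 is hydrogen in place of methyl on an aromatic carbon and gives a step that the two limits leave unreadable from compound 1 to compound 2, a step that cannot be read because both values sit at the limit of > 100000 nM in this assay, at which 2 of the 3 values shown sit. Compound 3 gives 30000 nM in this assay; how its core differs from that of compound 1 is not broken down here.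

Compound 4, `CSc1nc2sncc2n1[C@H]1C[C@H](O)[C@@H](CO)O1`, has not been measured. It carries the same change as that made from compound 1 to compound 2, namely (hydrogen in place of methyl on an aromatic carbon). Compound 4 is expected to give about 40000 nM in this assay, estimated between 15000 nM and 100000 nM. For compound 4 the expected step is a 1.3-fold higher number from compound 3 to compound 4 (0.12 log units; within the scatter). This rests on compound 3 giving 30000 nM and on the parallel step being unreadable, so a small step is assumed.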

Compound 4, half-maximal inhibitory concentration: 6000 nM
For compound 4 the middle estimate is 6.7-fold (0.82 log units) above the measured one; measured number outside the range, below it.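

In this assay hydrogen in place of methyl on an aromatic carbon gives a 5.0-fold lower number from compound 3 to compound 4 (0.70 log units; beyond the scatter) on this core. The same change on the core of compound 1 cannot be read, since compound 1 and compound 2 both sit at a limit of the assay rather than a number: the limit of > 100000 nM in this assay, at which 2 of the 4 values shown sit. The change therefore lowers the number in one readable pair only, and this does not show that the effect carries from one core to another.

The compounds shown leave open how an ethyl group, an amine or a carboxylic acid on that aromatic carbon would read in this assay against methyl and hydrogen.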